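Swapping the side chain on a biphenyl amide core

The source may report more compounds than this note shows. Statements on the series, on what has been measured and on what is new or still open speak of the compounds shown alone.

Of the compounds shown here, three with a shared core have been measured in a functional assay on MDA-MB-468 cells (Homo sapiens) for antiproliferative activity, read by MTT assay, with a stated time of 48 h; a lower number here means a stronger inhibitor, a higher number a weaker inhibitor. Compound 1 `CCCNc1cc2c(cn1)cc(NC(=O)c1cccc(-c3ccccc3)c1)c(=O)n2C` stands lowest of the three, with compound 1 giving 1870 nM. Compound 2 `CN(C)CCNc1cc2c(cn1)cc(NC(=O)c1ccncc1)c(=O)n2C` carries a pyridine amide in place of the biphenyl amide and a different side chain; in this assay compound 2 gives 8360 nM, a value beyond the scatter from compound 1. Compound 3 `COc1cc(C(=O)Nc2cc3cnc(NCCN(C)C)cc3n(C)c2=O)cc(OC)c1OC` carries a trimethoxyphenyl amide with the same side chain as compound 2, and in this assay compound 3 gives 15600 nM, the furthest from compound 1.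

Compound 4 `CN(C)CCNc1cc2c(cn1)cc(NC(=O)c1cccc(-c3ccccc3)c1)c(=O)n2C` keeps the biphenyl amide of compound 1 and takes the side chain of compounds 2 and 3. The change from compound 1 is dimethylamino in place of methyl on a saturated chain carbon, two bonds along the chain from a nitrogen on an aromatic ring. For the measured compounds named here, no pair of measured compounds isolates this change, so its size is unknown; compounds 2 and 3 differ from compound 1 in two places at once. The step of a 1.2-fold lower number from compound 1 to compound 4 (0.10 log units; within the scatter) is expected to be small and within the scatter. Compound 4 is estimated at 1500 nM, between 500 nM and 5000 nM.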

Compound 4, half-maximal inhibitory concentration: 1680 nM
Beside the measured number, compound 4's estimate is 1.1-fold (0.05 log units) below it; the range from low to high includes it.
By their numbers in this assay, from the lowest: compounds 4 and 1 (each within the scatter of the next); then compounds 2 and 3 (each within the scatter of the next).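

For the compounds shown here, with the biphenyl amide held fixed, the step of a 1.1-fold lower number from compound 1 to compound 4 (0.05 log units; within the scatter) in this assay gives the first direct reading of this change, and it shows that propylamino and (2-(dimethylamino)ethyl)amino are interchangeable here within the scatter. Compound 4 also carries the same side chain as compound 2 and compound 3, yet compound 4 gives 1680 nM, compound 2 gives 8360 nM and compound 3 gives 15600 nM, so this side chain occurs with both the lowest and the highest numbers in the set. No measurement in hand accounts for the lack of a clear step on this exchange.

The compounds shown leave open whether a longer chain, a morpholine or a carboxylic acid in place of the dimethylamino would keep the number in this range. They also do not show whether propylamino would read the same alongside the pyridine amide or the trimethoxyphenyl amide.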